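The compounds below may be only part of what the source reports. "The series", "measured", "known", "first", "only" and "open" are said of these compounds alone.

Measured compounds:
Compound 1, `O=C(/C=C/c1cn([C@H]2C[C@@H](CO)N(Cc3ccccc3)C2)nn1)NO`: 35%
Compound 2, `O=C(/C=C/c1cn([C@@H]2C[C@@H](CO)N(Cc3ccccc3)C2)nn1)NO`: < 10%

Among the compounds with values here, in an assay on Sf9 cells for inhibition of histone deacetylase 11 (Homo sapiens), read by fluorescence, tested at 0.5 uM (on this read-out higher numbers stand for more inhibition at the one concentration tested (going by the name of the read-out) and lower numbers for less inhibition), compound 1 gives 35%, the only number among the two values shown. Compound 2 gives < 10% in this assay, which is a limit of the assay and not a number. Within the data shown here, the one measured step is a number at least 25 percentage points lower from compound 1 to compound 2 (beyond the scatter), a change that rests on the limit of < 10% in this assay, at which 1 of the 2 values shown sits, and on (the fact that compounds 1 and 2 differ only in the configuration as drawn). That step concerns configuration alone, not the group on the saturated ring carbon, so it says nothing direct about the change now at hand.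

Compound 3, `O=C(/C=C/c1cn([C@H]2C[C@@H](C(=O)O)N(Cc3ccccc3)C2)nn1)NO`, differs from compound 1 by carboxy in place of hydroxymethyl on a saturated ring carbon. Among the measured compounds shown here, no measured pair covers a change of this kind, so the numbers give no basis for a step in either direction beyond the scatter. Compound 3 is therefore expected to stay near compound 1, with a wide range to reflect that uncertainty. The expected step is a number 7 percentage points lower from compound 1 to compound 3 (within the scatter). Compound 3 is estimated at 28%, between 5% and 55%.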

Compound 3, a percentage reported as inhibition, at one concentration (the size of the read-out at that concentration, not a potency): 23%
Beside the measured number, compound 3's estimate is 5 percentage points above it; low and high end bracket the measured number.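

In this assay, the step at this position is a number 12 percentage points lower from compound 1 to compound 3 (beyond the scatter), so the saturated ring carbon next to the ring nitrogen, until now seen only through a change of configuration at a different stereocentre, proves sensitive to the group it carries. Within the data shown here, the step is modest, and compound 3 still gives 23%, so hydroxymethyl is not the only group at this place with which a reading of inhibition is kept at the one concentration tested. Nothing given here bears on why carboxy in place of hydroxymethyl lowers the number, and the step stands as an observation without an explanation.

The compounds shown leave open whether the step is specific to carboxy or would be seen with other groups at this place, such as an amine, a methyl ester or a longer chain like hydroxyethyl, any of which could fall on either side of compound 1. Also open, on these data alone, is how the same exchange of hydroxymethyl for carboxy would read in the configuration of compound 2, and whether it would then move the number at all.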